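A few compounds are considered here, and "the series" means these few. Any claim that something is new, unique, unknown or untested is made for them only; others in the source may bear on it.

Series notes. Compound 1 `O=S(=O)(c1ccc(F)cc1)c1cn(C2CCNC2)c2ncccc12` gives 8.5 nM in an assay on HeLa cells for displacement of a labelled ligand from 5-hydroxytryptamine receptor 6 (Homo sapiens); a lower number here means a stronger inhibitor, a higher number a weaker inhibitor. Compound 2 `CN1CCC(n2cc(S(=O)(=O)c3ccc(F)cc3)c3cccnc32)C1` gives 5 nM in this assay. Going by the values given here, the single measured step, a 1.7-fold lower number from compound 1 to compound 2 (0.23 log units; within the scatter), alters only the amine nitrogen; the two numbers lie within the scatter of each other, so compound 2 holds the lower of the two numbers without standing apart from compound 1.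

Compound 3 `CN1CCC(n2cc(S(=O)(=O)c3ccc(Cl)cc3)c3cccnc32)C1` differs from compound 2 by chloro in place of fluoro on an aromatic carbon. Among the compounds with values here, no measured step touches the fluoro on the six-membered aromatic ring of carbon only, so the step from compound 1 to compound 2 does not bear on this change, and nothing on hand shows how far exchanging 4-fluorophenyl for 4-chlorophenyl shifts the number. The working expectation is therefore no step beyond the scatter, estimated as no change at the digits printed from compound 2 to compound 3 (within the scatter). Compound 3 is expected to give 5 nM in this assay, with a range from 2 nM to 13 nM.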

Compound 3, inhibition constant: 4.2 nM
For compound 3 the middle estimate is 1.2-fold (0.08 log units) above the measured one; the range from low to high includes it.
By their numbers in this assay, from the lowest: compounds 3, 2 and 1 (each within the scatter of the next, the first and the last beyond it).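

In this assay, going by these compounds alone, exchanging 4-fluorophenyl for 4-chlorophenyl gives a 1.2-fold lower number from compound 2 to compound 3 (0.08 log units; within the scatter), the first measured step at this place on the six-membered aromatic ring of carbon only. Fluoro and chloro therefore cannot be told apart here, and this place takes either group without a shift beyond the scatter, at least with methyl on the ring amine nitrogen. No supporting evidence on hand bears on this result.

Open, from the compounds shown here alone, is whether a different group at this place, such as methoxy, trifluoromethyl or a carboxylic acid, or plain hydrogen, moves the number beyond the scatter. Also open, going by these compounds, is whether the exchange of fluoro for chloro reads the same with hydrogen on the ring amine nitrogen, as in compound 1.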